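A few compounds are considered here, and "the series" means these few. Any claim that something is new, unique, unknown or untested is made for them only; others in the source may bear on it.

Compound 2 `CCCn1c(SCc2cc([N+](=O)[O-])ccc2OC)nc2cc(NC(=O)NC(C)(C)C)cc(C(=O)N(C)C)c21` gives 270 nM in an assay on isolated protein for inhibition of Gonadotropin-releasing hormone receptor (Homo sapiens) (a higher number here means a weaker inhibitor, a lower number a stronger inhibitor), the higher of the two numbers recorded so far; compound 1 `CCCn1c(SCc2cc([N+](=O)[O-])ccc2OC)nc2cc(NC(=O)NC(C)(C)C)cc(C(=O)OC)c21` gives 37 nM in this assay, and the step of a 7.3-fold higher number from compound 1 to compound 2 (0.86 log units; beyond the scatter) is the only one measured. Compound 3 `CCCn1c(SCc2cc([N+](=O)[O-])ccc2OC)nc2cc(NC(=O)NC(C)(C)C)cc(C(=O)NC(C)(C)C)c21` carries (tert-butyl)amino in place of dimethylamino on a carbonyl carbon. Going by the values given here, the single measured step bears on it only loosely, since that step exchanged methoxy for dimethylamino rather than one amine for another. No step beyond the scatter is therefore expected, with a 1.7-fold lower number from compound 2 to compound 3 (0.23 log units; within the scatter) as the working guess. Compound 3 is estimated at 160 nM in this assay, within 40 nM to 650 nM.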

Compound 3, half-maximal inhibitory concentration: 410 nM
Beside the measured number, compound 3's estimate is 2.6-fold (0.41 log units) below it; the measured number falls inside the stated range.
By their numbers in this assay, from the lowest: compound 1; then compounds 2 and 3 (each within the scatter of the next).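

In (this assay) the exchange of dimethylamino for (tert-butyl)amino on a carbonyl carbon gives (a 1.5-fold higher number from compound 2 to compound 3 (0.18 log units; within the scatter)), so the two amides, compound 2 and compound 3, cannot be told apart, even though the entering group adds a hydrogen-bond donor and more heavy atoms. Replacing methoxy with (tert-butyl)amino at the same place gives (an 11-fold higher number from compound 1 to compound 3 (1.04 log units; beyond the scatter)), so compound 1 stands apart from both amides. Nothing available accounts for these steps. On these data alone, whether methylamino, an unsubstituted amide or a carboxylic acid on this carbonyl carbon would stay with the amides or come closer to compound 1 remains open.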